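The compounds below may be only part of what the source reports. "The series", "measured", "known", "first", "only" and "open" are said of these compounds alone.

Compound 1 `COc1ccc(C2=NN(C3=NC(=O)/C(=C4\C(=O)Nc5ccccc54)S3)C(c3ccc(OC)cc3)C2)cc1` is the weakest of the three measured compounds in a functional assay on cells (Cancer cell lines, Homo sapiens) for cytotoxicity, read by sulforhodamine B assay, with a stated time of 48 h (a lower number here means a stronger inhibitor of growth, a higher number a weaker inhibitor of growth), where compound 1 gives 100000 nM. Two modifications of it have been measured. Compound 2 `COc1ccc(C2=NN(C3=NC(=O)/C(=C4\C(=O)Nc5ccc(Br)cc54)S3)C(c3ccc(OC)cc3)C2)cc1`, which carries bromo in place of hydrogen on an aromatic carbon, gives 380 nM in this assay, a step of a 260-fold lower number from compound 1 to compound 2 (2.42 log units; beyond the scatter). Compound 3 `COc1ccc(C2CC(c3ccc4ccccc4c3)=NN2C2=NC(=O)/C(=C3\C(=O)Nc4ccccc43)S2)cc1`, with naphthalen-2-yl in place of 4-methoxyphenyl on a carbon with a double bond to nitrogen, gives 13600 nM in this assay, a step of a 7.4-fold lower number from compound 1 to compound 3 (0.87 log units; beyond the scatter).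

Compound 4 `COc1ccc(C2=NN(C3=NC(=O)/C(=C4\C(=O)Nc5ccccc54)S3)C(c3ccc(Cl)cc3)C2)cc1` differs from compound 1 by chloro in place of methoxy on an aromatic carbon, set para to a large group on a six-membered aromatic ring of carbon only, so that 4-methoxyphenyl becomes 4-chlorophenyl. Neither measured step touches this ring, yet both show that a change on an aryl ring of this core lowered the number, once by a large and once by a modest amount. Among the compounds with values here, a lowering is therefore the more likely direction for compound 4 in this assay, though its size is uncertain and no direct precedent exists. Compound 4 is expected to show a step of a 5.0-fold lower number from compound 1 to compound 4 (0.70 log units; beyond the scatter) in this assay. The estimated value for compound 4 in this assay is 20000 nM, within a range from 3000 nM to 100000 nM.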

Compound 4, concentration for total growth inhibition: 100000 nM
Beside the measured number, compound 4's estimate is 5.0-fold (0.70 log units) below it, and the stated range covers the measured number.
By their numbers in this assay, from the lowest: compound 2; then compound 3; then compounds 1 and 4 (each within the scatter of the next).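

In this assay, the step reads no change at the digits printed from compound 1 to compound 4 (within the scatter), so replacing methoxy with chloro, which turns this 4-methoxyphenyl group into 4-chlorophenyl, gives no change at the digits printed. The earlier steps had shown only lower numbers, with bromo in place of hydrogen in compound 2 and with naphthalen-2-yl in place of the other 4-methoxyphenyl group, the one on a carbon with a double bond to nitrogen, in compound 3; this result shows that a change on an aromatic ring of the shared core need not lower the number, and compounds 2 and 3 go against any reading of this one step as general. No evidence is at hand that bears on this result.

The compounds shown leave open whether a different group at this place, such as an amine, a carboxylic acid or a longer alkoxy chain, would lower the number or leave it unchanged. They also leave open whether chloro in place of methoxy would again give no change on a core that carries the bromo of compound 2.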